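Three Compounds at the Limit and a Fourth Awaited

A few compounds are considered here, and "the series" means these few. Any claim that something is new, unique, unknown or untested is made for them only; others in the source may bear on it.

In a functional assay on NCI/ADR-RES cells (Homo sapiens) for inhibition, read by sulforhodamine B assay, with a stated time of 48 h (a lower number here means a stronger inhibitor of growth, a higher number a weaker inhibitor of growth), the measured compounds stand as follows.
Compound 1 `C=C(C)[C@@H]1CC=C(Cn2cc(COc3ccc(C4NC(=O)NC(C)=C4C(=O)OCC)cc3)nn2)CC1`: > 100000 nM.
Compound 2 `C=C(C)[C@@H]1CC=C(Cn2cc(COc3cccc(C4NC(=O)NC(C)=C4C(=O)OCC)c3)nn2)CC1`: > 100000 nM.
Compound 3 `C=C(C)[C@@H]1CC=C(Cn2cc(COc3ccc(C4NC(=O)NC(C)=C4C(C)=O)cc3)nn2)CC1`: > 100000 nM.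

Each of these values is a limit of this assay, not a number, and (the limit of > 100000 nM in this assay, at which 3 of the 3 values shown sit). Compound 3 differs from compound 1 by methyl in place of ethoxy on a carbonyl carbon, and the resulting step, a step that the two limits leave unreadable from compound 1 to compound 3, cannot be read because both ends sit at the limit. How the core of compound 2 differs from that of compound 1 is not broken down here. Compound 4 `C=C(C)[C@@H]1CC=C(Cn2cc(COc3cccc(C4NC(=O)NC(C)=C4C(C)=O)c3)nn2)CC1` differs from compound 2 by methyl in place of ethoxy on a carbonyl carbon, the same change as from compound 1 to compound 3. The step is expected to be a step that the limit leaves unreadable from compound 2 to compound 4 because the same change gave only a step that the two limits leave unreadable from compound 1 to compound 3. Compound 4 is therefore estimated at 150000 nM in this assay, most likely reported again as a limit only.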

Compound 4, concentration for total growth inhibition: > 100000 nM
Compound 4: a limit, no number; the forecaster's own chance of this, stated with the estimate: 90%; the middle value is on the limit's open side.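

Compound 2 and compound 4 both sit at a limit rather than a number, so no new step can be read between them: the limit of > 100000 nM in this assay, at which 4 of the 4 values shown sit. The compounds shown leave open how strongly any of them inhibits growth.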